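Morpholine amide in place of anilide in benzofuran ethers

A few compounds are considered here, and "the series" means these few. Any claim that something is new, unique, unknown or untested is made for them only; others in the source may bear on it.

Two compounds of this series have numbers in a functional assay on MCF7 cells (Homo sapiens) for antiproliferative activity, read by MTT assay, with a stated time of 24 h; a higher number here means a weaker inhibitor, a lower number a stronger inhibitor. Compound 1, `CCCCc1oc2ccccc2c1C(=O)c1ccc(OCC(=O)Nc2ccccc2)cc1`, gives 33600 nM. Compound 2, `CCCCc1oc2ccccc2c1C(=O)c1ccc(OCC(=O)Nc2cccc(OC)c2)cc1`, gives 38500 nM. Among the compounds with values here, the one step recorded, a 1.1-fold higher number from compound 1 to compound 2 (0.06 log units; within the scatter), concerns the methoxy in place of hydrogen on an aromatic carbon and does not separate the two compounds. Compound 2 therefore holds the higher of the two numbers only nominally, and no order between compound 1 and compound 2 can be read from them.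

Compound 3, `CCCCc1oc2ccccc2c1C(=O)c1ccc(OCCCC(=O)N2CCOCC2)cc1`, is not yet measured. Its difference from compound 2 is 2-((morpholin-4-yl)carbonyl)ethyl in place of (3-methoxyphenyl)carbamoyl on a saturated chain carbon bound to an oxygen on an aromatic ring. Within the data shown here, no measured step touches this change: the single step from compound 1 to compound 2 alters a group that is itself removed in compound 3, and it was within the scatter anyway. There is thus no basis in the numbers for expecting a shift in either direction beyond the scatter, and the estimate for compound 3 is accordingly wide.

On that basis the expected step is a 1.0-fold lower number from compound 2 to compound 3 (0.02 log units; within the scatter). Compound 3 is estimated at 37000 nM, with a range from 10000 nM to 130000 nM.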

Compound 3, half-maximal inhibitory concentration: 41200 nM
Beside the measured number, compound 3's estimate is 1.1-fold (0.05 log units) below it; the measured number falls inside the stated range.
By their numbers in this assay, from the lowest: compounds 1, 2 and 3 (each within the scatter of the next).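

In this assay, 2-((morpholin-4-yl)carbonyl)ethyl in place of (3-methoxyphenyl)carbamoyl on a saturated chain carbon bound to an oxygen on an aromatic ring gives a 1.1-fold higher number from compound 2 to compound 3 (0.03 log units; within the scatter), and the same group in place of phenylcarbamoyl gives a 1.2-fold higher number from compound 1 to compound 3 (0.09 log units; within the scatter). The earlier step altered only a methoxy on the aromatic ring, whereas these two remove the whole carbamoyl group, including its six-membered aromatic ring of carbon only and its hydrogen-bond donor, and still leave all three compounds within the scatter of one another, so neither feature is needed here to hold the number at this level. No separate measurement on these compounds bears on this result.

The morpholine ring and the change in chain enter in one step, so their separate contributions remain unresolved, and a morpholine amide on the shorter chain or an anilide on the longer chain would be needed to separate them. Also open, on these data alone, is whether any group at this position moves the number beyond the scatter, for example a carboxylic acid or a free amine at the end of the chain.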